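Amine substituent change: 1,1-dioxothian-4-yl for (thian-4-yl)methyl

The source may hold more compounds than are shown below. What is called first, only, known or untested is meant among the compounds shown, and "the series" means these compounds.

Measured so far:
Compound 1 `c1ccc(CN(CCCCN(C[C@H]2Cc3ccccc3CN2)[C@H]2CCCc3cccnc32)Cc2ccccn2)nc1`. In a functional assay on cells for agonist activity at C-X-C chemokine receptor type 4 (Homo sapiens), read by fluorescence and calcium flux, with a stated time of 90 s (on this read-out lower numbers stand for an effect already at smaller amounts and higher numbers for an effect only at larger amounts of compound), compound 1 gives > 30000 nM, which is a limit of the assay and not a number.
Compound 2 `c1ccc2c(c1)CN[C@@H](CN(CCCCN(Cc1ccncc1)Cc1ccncc1)[C@H]1CCCc3cccnc31)C2`. In this assay compound 2 gives > 30000 nM, again only a limit.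
Compound 3 `c1ccc2c(c1)CN[C@@H](CN(CCCCNCC1CCSCC1)[C@H]1CCCc3cccnc31)C2`. In this assay compound 3 gives > 30000 nM, likewise a limit.

Compound 3 thus stands at the limit of > 30000 nM in this assay, at which 3 of the 3 values shown sit. For the measured compounds named here, no numerical potency is known for it, and the same holds for the other two compounds, so no step between measured compounds can be read off this set and no direction of change is established.

Compound 4 `O=S1(=O)CCC(NCCCCN(C[C@H]2Cc3ccccc3CN2)[C@H]2CCCc3cccnc32)CC1` differs from compound 3 in one place: 1,1-dioxothian-4-yl in place of (thian-4-yl)methyl on an amine nitrogen. None of the values in hand bears on this change, as each of them is only a limit. In this assay the expected step is a number no higher from compound 3 to compound 4 (the limit leaves the size open), that is, no movement beyond the scatter, with the most likely outcome a further limit rather than a number. Compound 4 is expected at 30000 nM, with a range from 10000 nM to 100000 nM, and the assay is expected to report only a limit for it.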

Compound 4, half-maximal effective concentration: > 30000 nM
Compound 4 ended at the assay's limit; the forecaster's own chance of this, stated with the estimate: 85%; the middle value lies on the limit itself.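

No step can be read between compound 3 and compound 4 in this assay, as each value is only a limit of the assay: the limit of > 30000 nM in this assay, at which 4 of the 4 values shown sit.

The compounds shown leave open how 1,1-dioxothian-4-yl and (thian-4-yl)methyl compare on an amine nitrogen, and whether any substituent there gives a numerical half-maximal effective concentration on the shared core.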